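A few compounds are considered here, and "the series" means these few. Any claim that something is new, unique, unknown or untested is made for them only; others in the source may bear on it.

Of the compounds shown here, three sharing one core have so far been measured in an assay on isolated protein for inhibition of histone deacetylase 4 (Homo sapiens), with a stated time of 1 h; on this read-out lower numbers stand for stronger inhibition and higher numbers for weaker inhibition. Compound 1 `COc1cccc(NC(=O)COc2ccc3cc(/C=C4/SC(=O)NC4=O)ccc3c2)c1` gives 1600 nM, compound 2 `O=C(COc1ccc2cc(/C=C3/SC(=O)NC3=O)ccc2c1)Nc1cccc(C(F)(F)F)c1` gives 2500 nM, and compound 3 `COc1ccc(NC(=O)COc2ccc3cc(/C=C4/SC(=O)NC4=O)ccc3c2)cc1` gives 4700 nM. On these numbers compound 2 stands second highest of the three: it sits nearest to compound 1, with a step of a 1.6-fold higher number from compound 1 to compound 2 (0.19 log units; within the scatter), and furthest from compound 3, with a step of a 1.9-fold higher number from compound 2 to compound 3 (0.27 log units; within the scatter), both within the scatter. Among the compounds with values here, the only step that reaches beyond the scatter is a 2.9-fold higher number from compound 1 to compound 3 (0.47 log units; beyond the scatter), and it is a modest one.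

Compound 4 `Cc1cc(NC(=O)COc2ccc3cc(/C=C4/SC(=O)NC4=O)ccc3c2)no1` has not yet been measured. It differs from compound 2 in one place: 5-methyl-1,2-oxazol-3-yl in place of 3-(trifluoromethyl)phenyl on an amide-type nitrogen.

All three measured steps swap one substituted phenyl for another on the same amide-type nitrogen, and each was small. Within the data shown here, no measured step replaces that phenyl with a five-membered aromatic ring carrying hetero atoms, so the change leading to compound 4 goes further than anything yet measured, and it is hard to say which way the number will move. The expectation in this assay is therefore a step of at most modest size, with wide uncertainty. For compound 4 the estimate is 3000 nM, within a range from 1000 nM to 9000 nM, which means an expected step of a 1.2-fold higher number from compound 2 to compound 4 (0.08 log units; within the scatter).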

Compound 4, half-maximal inhibitory concentration: 1700 nM
Compound 4: middle estimate off by 1.8-fold (0.25 log units), on the high side; the range from low to high includes it.
By their numbers in this assay, from the lowest: compounds 1, 4, 2 and 3 (each within the scatter of the next, the first and the last beyond it).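

On this amide-type nitrogen, this assay shows that the substituted phenyl need not stay: a five-membered aromatic ring with 2 hetero atoms can take its place, as a 1.5-fold lower number from compound 2 to compound 4 (0.17 log units; within the scatter) and a 1.1-fold higher number from compound 1 to compound 4 (0.03 log units; within the scatter) are both within the scatter. Within the data shown here, this holds even though the entering group has fewer heavy atoms than 3-(trifluoromethyl)phenyl, and 2 hydrogen-bond acceptors where that group has 0, while a 2.8-fold lower number from compound 3 to compound 4 (0.44 log units; beyond the scatter) is the only new step beyond the scatter and it is modest. So the change of ring type moves the number no further than the earlier swaps among phenyl groups did, and nothing available here explains why the number responds so little.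

Still open, from the compounds shown here alone, is what the methyl of the 5-methyl-1,2-oxazol-3-yl group contributes, and whether an unsubstituted phenyl, a pyridine ring, or a ring carrying an amine or a carboxylic acid would stay in the same range. These four compounds also cannot tell whether any group on this nitrogen could produce a large step at all, since every step seen so far is small or modest.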